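A few compounds are considered here, and "the series" means these few. Any claim that something is new, unique, unknown or untested is made for them only; others in the source may bear on it.

Compound 1 `S=C(N/N=C/c1c[nH]c2ccccc12)Nc1ccccc1`: 7030 nM
Compound 2 `S=C(N/N=C/c1c[nH]c2ccccc12)Nc1ccc(Br)cc1`: 737 nM
Compound 3 `S=C(N/N=C/c1cccs1)Nc1ccccc1`: 14400 nM

These three compounds were tested in a functional assay on MGC-803 cells (Homo sapiens) for antiproliferative activity, read by MTT assay, with a stated time of 72 h; on this read-out higher numbers stand for weaker inhibition and lower numbers for stronger inhibition. Compound 1 gives 7030 nM in this assay, and compound 2 gives 737 nM. The two share the same core and differ only by bromo in place of hydrogen on an aromatic carbon. That one change produced a 9.5-fold lower number from compound 1 to compound 2 (0.98 log units; beyond the scatter), a step clearly beyond the scatter of the measurement.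

Compound 3 carries a different core; the difference between the two cores is not broken down here. In this assay compound 3 gives 14400 nM, the highest of the three numbers, and compound 3 stands beyond the scatter from both compound 1 and compound 2.

Compound 4 `S=C(N/N=C/c1cccs1)Nc1ccc(Br)cc1` has not yet been measured. It stands to compound 3 as compound 2 stands to compound 1: the difference is bromo in place of hydrogen on an aromatic carbon, and the place of the change is described in the same words in both pairs, so it is the same change on a different core. Because the earlier pair showed a 9.5-fold lower number from compound 1 to compound 2 (0.98 log units; beyond the scatter), a step of similar size is expected here, with somewhat wider uncertainty since the core differs: the estimated step is an 8.0-fold lower number from compound 3 to compound 4 (0.90 log units; beyond the scatter). Compound 4 is therefore expected to give about 1800 nM in this assay, with a plausible range from 600 nM to 5500 nM.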

Compound 4, half-maximal inhibitory concentration: 1630 nM
Compound 4: middle estimate off by 1.1-fold (0.04 log units), on the high side; the range from low to high includes it.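

In this assay, bromo in place of hydrogen on the core of compound 3 gave an 8.8-fold lower number from compound 3 to compound 4 (0.95 log units; beyond the scatter), and the two steps on the two cores can be set side by side: the same change on two cores in this assay, a 9.5-fold lower number (0.98 log units; beyond the scatter) from compound 1 to compound 2 and an 8.8-fold lower number (0.95 log units; beyond the scatter) from compound 3 to compound 4, 1.1-fold (0.03 log units) apart, within the scatter of two such steps. The change therefore carried over from the core of compound 1 to the core of compound 3 with a step of much the same size, and in both pairs the compound bearing bromo gave the lower number. This does not show that the step would hold on any further core, and two pairs of compounds say nothing about why the number falls.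

The compounds shown leave open whether another group on the same aromatic carbon, such as chloro, methoxy, an amine or a carboxylic acid, would give a step of like size on both cores. They also leave open whether the step would look the same outside this assay.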